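The compounds below may be only part of what the source reports. "The series", "measured", "known", "first", "only" and "open" are said of these compounds alone.

Values so far in a functional assay on A2780 cells (Homo sapiens) for antiproliferative activity, read by resazurin assay, with a stated time of 72 h; a lower number here means a stronger inhibitor, a higher number a weaker inhibitor

Compound 1 `CN(Cc1ccccc1)C(=O)c1cc2c(Cc3ccccc3)n[nH]c2cc1O` gives 980 nM
Compound 2 `CN(Cc1ccccc1F)C(=O)c1cc2c(Cc3ccccc3)n[nH]c2cc1O` gives 1500 nM
Compound 3 `CN(Cc1ccccc1Br)C(=O)c1cc2c(Cc3ccccc3)n[nH]c2cc1O` gives 1200 nM

Compound 3, at 1200 nM, cannot be separated from the other two compounds, since all three values lie within the scatter of one another. Compound 4 `CN(Cc1cccc(Br)c1)C(=O)c1cc2c(Cc3ccccc3)n[nH]c2cc1O` has the same atoms as compound 3, joined differently: 3-bromophenyl in place of 2-bromophenyl on a saturated chain carbon bound to an amide-type nitrogen. The same difference, cut one bond further out, reads 2-bromobenzyl to 3-bromobenzyl.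

Going by the values given here, no measured step moves the bromine itself, so the evidence is indirect. Among the compounds with values here, three steps bear on the change, all made on the same ring. Adding bromo gave a 1.2-fold higher number from compound 1 to compound 3 (0.09 log units; within the scatter), adding fluoro gave a 1.5-fold higher number from compound 1 to compound 2 (0.18 log units; within the scatter), and exchanging fluoro for bromo gave a 1.3-fold lower number from compound 2 to compound 3 (0.10 log units; within the scatter). None of these leaves the scatter, so this ring has so far tolerated each change tried on it. However, the data hold no compound with any group at the new place, which widens the uncertainty. No step beyond the scatter is expected in this assay, and no direction can be favoured. The estimated step is a 1.1-fold lower number from compound 3 to compound 4 (0.04 log units; within the scatter). Compound 4 is expected at about 1100 nM, with an estimated range of 500 nM to 2500 nM.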

Compound 4, half-maximal inhibitory concentration: 7100 nM
For compound 4 the middle estimate is 6.5-fold (0.81 log units) below the measured one; the whole stated range lies below it.
By their numbers in this assay, from the lowest: compounds 1, 3 and 2 (each within the scatter of the next); then compound 4.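

In this assay, going by these compounds alone, bromine's place on the ring matters: 2-bromophenyl to 3-bromophenyl gives a 5.9-fold higher number from compound 3 to compound 4 (0.77 log units; beyond the scatter) and is the first change on this ring to leave the scatter. The earlier replacements had suggested a tolerant ring, yet that tolerance covers only the unsubstituted phenyl, 2-fluorophenyl and 2-bromophenyl compounds, which remain inseparable from one another. Compound 4 stands apart from both other comparators, with a 7.2-fold higher number from compound 1 to compound 4 (0.86 log units; beyond the scatter) and a 4.7-fold higher number from compound 2 to compound 4 (0.68 log units; beyond the scatter) in the same direction, making it the weakest of the four compounds shown. No measurement available here accounts for this difference.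

On these data alone, whether methoxy, a nitrile or an amine at the place bromine takes in 3-bromophenyl would match bromine in this assay, and so whether the loss follows the place or bromine itself, stays open. Also open, as far as these compounds go, is whether a longer chain between the amide-type nitrogen and the ring would keep, shrink or widen the gap between the 2-bromophenyl and 3-bromophenyl compounds.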